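A few compounds are considered here, and "the series" means these few. Any claim that something is new, unique, unknown or untested is made for them only; others in the source may bear on it.

Working notes on the series in an in vivo ADME assay on the whole organism for pharmacokinetics, with Rattus norvegicus as the target, at a dose of 20 mg/kg; a lower number here means less compound in the circulation, a higher number more compound in the circulation at the dose given.

Three compounds carry numbers. Compound 1 `Cn1cc(C(=O)O)c(=O)c2cc(F)c(N3CCN(c4ccccn4)CC3)c(C(F)(F)F)c21` gives 58700 nM. Compound 3 `Cn1cc(C(=O)O)c(=O)c2cc(F)c(N3CCN(c4ncccn4)CC3)c(C(F)(F)F)c21` gives 130000 nM. Compound 2 `O=C(O)c1cn(C2CC2)c2c(C(F)(F)F)c(N3CCN(c4ncccn4)CC3)c(F)cc2c1=O` gives 14700 nM. Compound 1 thus stands second highest of the three: compound 3 lies a 2.2-fold higher number from compound 1 to compound 3 (0.35 log units; beyond the scatter) away from it, while compound 2 sits furthest below it. The two steps recorded are a 2.2-fold higher number from compound 1 to compound 3 (0.35 log units; beyond the scatter) for pyrimidin-2-yl in place of pyridin-2-yl on an amine nitrogen in a ring, and an 8.8-fold higher number from compound 2 to compound 3 (0.95 log units; beyond the scatter) for methyl in place of cyclopropyl on an aromatic nitrogen.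

Compound 4 `CCn1cc(C(=O)O)c(=O)c2cc(F)c(N3CCN(c4ccccn4)CC3)c(C(F)(F)F)c21` differs from compound 1 by methyl in place of hydrogen on a saturated chain carbon bound to an aromatic nitrogen. Among the compounds with values here, of the measured steps, only the one from compound 2 to compound 3 touches the same aromatic nitrogen; there a smaller group gave the higher number, so the step to a larger group here is read in the opposite direction, and tempered because an 8.8-fold higher number from compound 2 to compound 3 (0.95 log units; beyond the scatter) compared a ring with a one-carbon group rather than one chain with another. The step from compound 1 to compound 3 concerns another place and gives no direct guidance. For compound 4 a modest decrease is expected, a 1.7-fold lower number from compound 1 to compound 4 (0.22 log units; within the scatter), with an estimate of 35000 nM in the range 15000 nM to 90000 nM.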

Compound 4, maximal plasma concentration: 14500 nM
Estimate against measurement, compound 4: 2.4-fold (0.38 log units) above, outside the stated range (below it).
By their numbers in this assay, from the lowest: compounds 4 and 2 (each within the scatter of the next); then compound 1; then compound 3.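

In this assay, the aromatic nitrogen of the shared core proves sensitive to a single added carbon and not only to a change to a ring: methyl to ethyl gives a 4.0-fold lower number from compound 1 to compound 4 (0.61 log units; beyond the scatter) and counts as a step beyond the scatter. Read with an 8.8-fold higher number from compound 2 to compound 3 (0.95 log units; beyond the scatter) as the other step at this nitrogen, the methyl compound carries the higher number in both pairs, although one pair has pyridin-2-yl and the other pyrimidin-2-yl on the amine nitrogen in a ring. Nothing at hand explains why the number falls with the ethyl group.

On these data alone, whether the step from methyl to ethyl keeps its size with pyrimidin-2-yl in place of pyridin-2-yl remains open. The compounds shown also leave open how a longer chain such as propyl, or a chain ending in a hydroxyl group, would read at this nitrogen.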